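The compounds below may be only part of what the source reports. "The series", "measured", "known", "first", "only" and "open" are said of these compounds alone.

The three measured compounds share one core and differ in the group on the amino nitrogen. Compound 1 `CC(C)c1ccc(-c2nc(SCc3cn(CC(=O)NC(=O)Nc4ccccn4)nn3)nc(Nc3ccc(F)cc3)c2C#N)cc1` carries 4-fluorophenyl there. In a functional assay on MCF7 cells (Homo sapiens) for inhibition, read by MTT assay, with a stated time of 72 h (a lower number here means a stronger inhibitor, a higher number a weaker inhibitor), compound 1 reaches only a limit, > 64000 nM. Compound 2 `CC(C)c1ccc(-c2nc(SCc3cn(CC(=O)NC(=O)Nc4ccccn4)nn3)nc(Nc3cccc([N+](=O)[O-])c3)c2C#N)cc1` carries 3-nitrophenyl, and in this assay compound 2 gives 25900 nM. Compound 3 `Cc1ccc(Nc2nc(SCc3cn(CC(=O)NC(=O)Nc4ccccn4)nn3)nc(-c3ccc(C(C)C)cc3)c2C#N)cc1` carries 4-methylphenyl. In this assay compound 3 again reaches only a limit, > 64000 nM. Compound 3 thus stands at the weak edge of what was measured, sharing the limit with compound 1, as the limit of > 64000 nM in this assay, at which 2 of the 3 values shown sit, records. The measured steps run an at least 2.4-fold lower number from compound 1 to compound 2 (0.39 log units; beyond the scatter), a step that the two limits leave unreadable from compound 1 to compound 3 and an at least 2.4-fold higher number from compound 2 to compound 3 (0.39 log units; beyond the scatter), and every one of them alters only the group on the amino nitrogen.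

Compound 4 `COc1cc(-c2nc(SCc3cn(CC(=O)NC(=O)Nc4ccccn4)nn3)nc(Nc3ccc(C)cc3)c2C#N)cc(OC)c1OC` changes a different place: 3,4,5-trimethoxyphenyl in place of 4-isopropylphenyl on an aromatic carbon. Among the compounds with values here, no measured step touches this position, so none of the three bears on the change, and its direction in this assay cannot be read from these compounds. The estimate is therefore anchored on the limit of compound 3 and left wide. Within the data shown here, the estimated step is an at least 1.2-fold lower number from compound 3 to compound 4 (0.10 log units; that floor lies within the scatter), with no measured step to support a direction. Compound 4 is expected to give about 50000 nM in this assay, within a range from 8000 nM to 200000 nM.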

Compound 4, half-maximal inhibitory concentration: 21000 nM
For compound 4 the middle estimate is 2.4-fold (0.38 log units) above the measured one; the measured number falls inside the stated range.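

The result shows that the aromatic carbon opposite the ring nitrogen, ortho to the cyano group, also matters in this assay: 3,4,5-trimethoxyphenyl in place of 4-isopropylphenyl gives an at least 3.0-fold lower number from compound 3 to compound 4 (0.48 log units; beyond the scatter) on the shared core. Within the data shown here, until this point, only changes to the group on the amino nitrogen had moved the read-out, so this is the first readable effect of a change elsewhere on the core, and it comes with 3 hydrogen-bond acceptors entering where the leaving group had 0. Compound 3 stands only at a limit, so this step has a floor and no exact size: the limit of > 64000 nM in this assay, at which 2 of the 4 values shown sit.

The compounds shown leave open whether all three methoxy groups are needed for this shift, or whether a single methoxy group, a hydroxyl group or an amine on the same phenyl ring would give a similar number. They also leave open whether 3,4,5-trimethoxyphenyl would lower the number to the same extent with 3-nitrophenyl or 4-fluorophenyl on the amino nitrogen in place of 4-methylphenyl.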